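Trifluoromethyl for nitrile at the amide-bearing ring

A few compounds are considered here, and "the series" means these few. Any claim that something is new, unique, unknown or untested is made for them only; others in the source may bear on it.

The compounds measured in an ADME assay on Huh-7 cells (Homo sapiens) for cytotoxicity; on this read-out lower numbers stand for higher toxicity in this test and higher numbers for lower toxicity in this test:
compound 1, `O=C(NC(=S)N1CCc2ccc(OCc3ccccc3)cc21)c1ccccc1`, gives 43800 nM.
compound 2, `O=C(NC(=S)N1CCc2c(OCCCCCOc3ccc(Cl)cc3)cccc21)c1ccc([N+](=O)[O-])cc1`, gives 13600 nM.
compound 3, `N#Cc1ccc(C(=O)NC(=S)N2CCc3c(OCCCCCOc4ccc(Cl)cc4)cccc32)cc1`, is reported only as > 50000 nM, which is a limit of this assay and not a number.

Compound 3 therefore stands at the top of what this assay can report: the only thing known is that its number lies past (the limit of > 50000 nM in this assay, at which 1 of the 3 values shown sits). Within the data shown here, the one measured step that reaches it, an at least 3.6-fold higher number from compound 2 to compound 3 (0.56 log units; beyond the scatter), shows that exchanging the group on the outer ring can move the number by a meaningful amount in this assay.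

Compound 4, `O=C(NC(=S)N1CCc2c(OCCCCCOc3ccc(Cl)cc3)cccc21)c1ccc(C(F)(F)F)cc1`, differs from compound 3 in exactly that place: trifluoromethyl in place of cyano on an aromatic carbon. Among the measured compounds shown here, no measured pair contains a trifluoromethyl group, so nothing shows how far this particular exchange moves the number. The nitro compound 2 and the nitrile compound 3 bracket the range in which compound 4 is expected to fall, and the estimate is therefore placed below the limit, as a step of an at least 1.4-fold lower number from compound 3 to compound 4 (0.15 log units; that floor lies within the scatter), with a wide range. Compound 4 is expected to give about 35000 nM, between 12000 nM and 50000 nM.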

Compound 4, half-maximal cytotoxic concentration: 32700 nM
For compound 4 the middle estimate is 1.1-fold (0.03 log units) above the measured one; low and high end bracket the measured number.
By their numbers in this assay, from the lowest: compound 2; then compounds 4 and 1 (each within the scatter of the next). At a limit, above all of these: compound 3.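

In this assay, among these compounds, the step to the trifluoromethyl group gives a 2.4-fold higher number from compound 2 to compound 4 (0.38 log units; beyond the scatter), so this position now has two groups, nitrile and trifluoromethyl, that each read higher than nitro, meaning lower toxicity in this test, when only that one group on the outer ring is exchanged. The comparison with the nitrile is much less firm: an at least 1.5-fold lower number from compound 3 to compound 4 (0.18 log units; that floor lies within the scatter), and this does not establish that trifluoromethyl and nitrile truly differ at this position. Compound 3 is reported only at a limit, which is not a number: the limit of > 50000 nM in this assay, at which 1 of the 4 values shown sits.

As far as these compounds go, what remains open is how other groups on this same aromatic carbon would read, such as an amine, a carboxylic acid or a methoxy group, and so whether the higher numbers relative to nitro extend beyond these two replacements. From the compounds shown here alone, it is also open whether the same order among nitro, nitrile and trifluoromethyl would hold with a shorter chain on the other side of the molecule.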